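Shortening the bromoalkoxy chain on the isoflavone-type core

The source may hold more compounds than are shown below. What is called first, only, known or untested is meant among the compounds shown, and "the series" means these compounds.

Measured so far:
compound 1 `O=c1c(-c2ccc(O)cc2)coc2cc(OCCCCCCBr)ccc12` — 2000 nM
compound 2 `O=c1c(-c2ccc(O)cc2)coc2cc(OCCC3OCCCO3)ccc12` — 7000 nM

In an assay on isolated protein (Cricetulus griseus) for inhibition of Monoamine oxidase (Homo sapiens) (a higher number here means a weaker inhibitor, a lower number a stronger inhibitor), compound 1 gives 2000 nM, the lowest of the two numbers; its nearest neighbour, compound 2, gives 7000 nM. For the measured compounds named here, the one measured step, a 3.5-fold higher number from compound 1 to compound 2 (0.54 log units; beyond the scatter), concerns a different change and does not bear directly on the one considered here.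

Compound 3 `O=c1c(-c2ccc(O)cc2)coc2cc(OCCCBr)ccc12` differs from compound 1 as follows: bromo in place of 3-bromopropyl on a saturated chain carbon, three bonds along the chain from an oxygen on an aromatic ring. Going by the values given here, with no measured step on this change, a modest movement in either direction is expected, with a weaker outcome slightly more likely; the step of a 1.5-fold higher number from compound 1 to compound 3 (0.18 log units; within the scatter) is the estimate. Compound 3 is expected to give 3000 nM, in the range 800 nM to 12000 nM.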

Compound 3, half-maximal inhibitory concentration: 150 nM
For compound 3 the middle estimate is 20-fold (1.30 log units) above the measured one; measured number outside the range, below it.
By their numbers in this assay, from the lowest: compound 3; then compound 1; then compound 2.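

In this assay, replacing 6-bromohexyl with 3-bromopropyl gives a 13-fold lower number from compound 1 to compound 3 (1.12 log units; beyond the scatter), a larger move than the earlier pair showed and the first sign that chain length at this position strongly affects the number. The same compound also stands far from the ring-bearing chain, with a 47-fold lower number from compound 2 to compound 3 (1.67 log units; beyond the scatter) in the listed comparison. Nothing available explains this shift. Whether the number changes steadily with length remains open, since 2-bromoethyl and 4-bromobutyl chains are not among the compounds shown. Also open, as far as these compounds go, is what the terminal bromine contributes, which an amine or a hydroxyl at the chain end could test.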